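Methyl for Methoxy: Expected Tolerance of Compound 3

The source may hold more compounds than are shown below. What is called first, only, known or untested is meant among the compounds shown, and "the series" means these compounds.

compound 1 `O=C(COc1cccc2ccccc12)N/N=C/c1ccc(F)cc1`: 100 ug/mL
compound 2 `COc1ccc(/C=N/NC(=O)COc2cccc3ccccc23)cc1`: 20 ug/mL

In an ADME assay on HEL cells (Homo sapiens) for cytotoxicity (a higher number here means that more compound is tolerated, a lower number that less compound is tolerated), compound 1 gives 100 ug/mL, while compound 2 gives 20 ug/mL. For the measured compounds named here, compound 2 thus holds the lower of the two numbers, the only measured step being a 5.0-fold lower number from compound 1 to compound 2 (0.70 log units; beyond the scatter), which is beyond the scatter and modest in size.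

Compound 3 `Cc1ccc(/C=N/NC(=O)COc2cccc3ccccc23)cc1` differs from compound 2 by methyl in place of methoxy on an aromatic carbon. Going by the values given here, no measured step exchanges methyl for methoxy. Among the compounds with values here, the one step at hand, a 5.0-fold lower number from compound 1 to compound 2 (0.70 log units; beyond the scatter), concerns fluoro giving way to methoxy at the same aromatic carbon and lowered the number. With methoxy now leaving and methyl entering, the number in this assay is expected to move part of the way back toward that of compound 1, though the size of that return is uncertain. Compound 3 is therefore estimated at 50 ug/mL, with a likely range from 20 ug/mL to 100 ug/mL. The expected step is a 2.5-fold higher number from compound 2 to compound 3 (0.40 log units; beyond the scatter).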

Compound 3, minimum cytotoxic concentration in the HEL assay: 20 ug/mL
Estimate against measurement, compound 3: 2.5-fold (0.40 log units) above; the measured number falls inside the stated range.
By their numbers in the HEL assay, from the lowest: compounds 2 and 3 (each within the scatter of the next); then compound 1.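

For the compounds shown here, at this position, the HEL assay does not separate methyl from methoxy: the result is no change at the digits printed from compound 2 to compound 3 (within the scatter), whereas the earlier compounds showed only that methoxy gave a lower number than fluoro. Methyl also gives a lower number than fluoro, with a 5.0-fold lower number from compound 1 to compound 3 (0.70 log units; beyond the scatter), so compound 1 stands alone above the two compounds that lack fluoro. The same exchange does separate the compounds in a physicochemical assay for lipophilicity, measured as octanol-water partition (on this read-out higher numbers stand for higher lipophilicity and lower numbers for lower lipophilicity), where compound 2 gives 3.77 and compound 3 gives 4.49, so this read-out moves while the number for tolerated compound does not.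

The compounds shown leave open whether the higher number of compound 1 is peculiar to fluoro. They also leave open where a chloro atom, a hydroxyl or an amine at this aromatic carbon would fall in the HEL assay.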